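Halogenated phenyl on the unmethylated core of compound 1

The source may report more compounds than this note shows. Statements on the series, on what has been measured and on what is new or still open speak of the compounds shown alone.

Measured compounds:
compound 1 `c1ccc(-c2cc(-c3cnn(C4CCNCC4)c3)on2)cc1`: 100000 nM
compound 2 `Cc1c(-c2cc(-c3ccccc3)no2)cnn1C1CCNCC1`: 1200 nM
compound 3 `Cc1c(-c2cc(-c3c(F)cccc3Cl)no2)cnn1C1CCNCC1`: 6 nM

In an assay on isolated protein for positive allosteric modulation of Neuronal acetylcholine receptor; alpha4/beta2 (Homo sapiens) (on this read-out higher numbers stand for an effect only at larger amounts of compound and lower numbers for an effect already at smaller amounts), compound 1 gives 100000 nM, the highest number of the three measured; compound 2 is nearest to it, compound 3 furthest. The change under review leads from compound 1 to the unmeasured compound 4 `Fc1ccc(Cl)c(-c2cc(-c3cnn(C4CCNCC4)c3)on2)c1`: 2-chloro-5-fluorophenyl in place of phenyl on an aromatic carbon. Among the compounds with values here, one measured step bears on it: the exchange of phenyl for a halogenated phenyl at this position gave a 200-fold lower number from compound 2 to compound 3 (2.30 log units; beyond the scatter), a large move downward, although that step was run on the methylated core and with a 2-chloro-6-fluorophenyl rather than the 2-chloro-5-fluorophenyl entering here. The other measured step, an 83-fold lower number from compound 1 to compound 2 (1.92 log units; beyond the scatter), concerns the methyl and not this exchange, so it does not carry over directly. A large downward step is therefore expected, tempered by the different halogen pattern and the absent methyl. Compound 4 is estimated at 3000 nM in this assay, within 300 nM to 30000 nM, which means an expected step of a 33-fold lower number from compound 1 to compound 4 (1.52 log units; beyond the scatter).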

Compound 4, half-maximal effective concentration: 270 nM
Estimate against measurement, compound 4: 11-fold (1.05 log units) above; the whole stated range lies above it.
By their numbers in this assay, from the lowest: compound 3; then compound 4; then compound 2; then compound 1.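

In this assay, 2-chloro-5-fluorophenyl in place of phenyl gives a 370-fold lower number from compound 1 to compound 4 (2.57 log units; beyond the scatter) on the core of compound 1, so a large downward move at this position does not require the methyl. The earlier large move for a halogenated phenyl, a 200-fold lower number from compound 2 to compound 3 (2.30 log units; beyond the scatter), stood only on the methylated core and with a different halogen pattern, so this position now responds strongly on both cores. No measurement shown gives a reason for the size of this step.

Compound 3 and compound 4 differ in two places, which leaves the shares of the halogen pattern and the methyl unseparated. Also open, from the compounds shown here alone, is whether the chlorine and fluorine are both needed, and whether a methoxy or trifluoromethyl group could replace either halogen on this phenyl.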